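The compounds below may be only part of what the source reports. "The series", "measured", "known", "first", "only" and "open" are said of these compounds alone.

Compound 1 `COc1cccc(CNCCCNc2ccnc3cc(Oc4ccccc4)ccc23)c1O` gives 317 10^-6 cm/s in an ADME assay for permeability, using PAMPA, with a stated time of 30 min, at pH 7.4; on this read-out higher numbers stand for higher permeability and lower numbers for lower permeability. Compound 2 `CC(C)(C)c1ccc(Oc2ccc3c(NCCCNCc4ccco4)ccnc3c2)cc1` gives 317 10^-6 cm/s and compound 3 `COc1ccc(F)cc1CNCCCNc1ccnc2cc(Oc3ccccc3)ccc12` gives 317 10^-6 cm/s in this assay, so compound 1 stands level with both at the digits shown, with compound 2 as its nearest neighbour and compound 3 as its furthest, neither differing from it beyond the scatter. Going by the values given here, the only measured step, no change at the digits printed from compound 1 to compound 3 (within the scatter), replaced one aryl group on the chain by another without effect. Compound 4 `COc1cccc(CNCCCNc2ccnc3cc(Cc4ccccc4)ccc23)c1O` differs from compound 1 by benzyl in place of phenoxy on an aromatic carbon. Among the compounds with values here, no measured step touches that part of the shared core, and the single step available gave no change, so the expected step is a 1.1-fold lower number from compound 1 to compound 4 (0.02 log units; within the scatter). Compound 4 is therefore estimated at 300 10^-6 cm/s, probably between 180 10^-6 cm/s and 320 10^-6 cm/s.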

Compound 4, apparent permeability: 23 10^-6 cm/s
The estimate for compound 4 lay 13-fold (1.12 log units) above the measured number, outside the stated range (below it).
By their numbers in this assay, from the lowest: compound 4; then compounds 1, 2 and 3 (each within the scatter of the next).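

The earlier step changed an aryl group on the chain and left the number where it was, whereas this change on the shared core gives, in this assay, a 14-fold lower number from compound 1 to compound 4 (1.14 log units; beyond the scatter). This position therefore matters for the read-out, even though the swap only puts a carbon in place of the oxygen of phenoxy and keeps the six-membered aromatic ring of carbon only. Nothing measured here explains the drop.

On these data alone, it remains open whether an amine or a phenylthio group at this position would stay close to compound 1 or to compound 4. As far as these compounds go, it is equally open whether the same swap would give a similar step with the chain groups of compound 2 or compound 3.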